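Swapping a methoxypyridine amide for a hydroxyphenyl amide

This account rests on a few compounds, and the source may have more. Where it says the series, first, only, none or still open, it means among the compounds named here.

Compound 2 `COc1cncc(C(=O)Nc2cnn(Cc3c(C)noc3C)c2)c1` gives the lowest number of the three measured compounds in a functional assay on cells for antagonist activity at taste receptor type 2 member 8 (Homo sapiens), read by FLIPR and calcium flux, with a stated time of 100 s (on this read-out higher numbers stand for weaker inhibition and lower numbers for stronger inhibition), at 800 nM. Compound 1 `Cc1noc(C)c1Cn1cc(NC(=O)c2ccccn2)cn1` gives 2300 nM, and compound 3 `COc1ccccc1C(=O)Nc1cnn(Cc2c(C)noc2C)c1` gives 1900 nM. Compound 4 `Cc1noc(C)c1Cn1cc(NC(=O)c2ccccc2O)cn1` has not yet been measured; it differs from compound 2 in one place: 2-hydroxyphenyl in place of 5-methoxypyridin-3-yl on a carbonyl carbon. The closest guide is the step of a 2.4-fold higher number from compound 2 to compound 3 (0.38 log units; beyond the scatter), in which 2-methoxyphenyl likewise replaced 5-methoxypyridin-3-yl on a carbonyl carbon; the step of a 1.2-fold lower number from compound 1 to compound 3 (0.08 log units; within the scatter) shows that the phenyl amide of compound 3 sits near compound 1. A step of similar size and direction in this assay is therefore expected, namely a 2.3-fold higher number from compound 2 to compound 4 (0.35 log units; beyond the scatter). The expected value for compound 4 is 1800 nM, within a range from 700 nM to 4500 nM.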

Compound 4, half-maximal inhibitory concentration: 1000 nM
For compound 4 the middle estimate is 1.8-fold (0.26 log units) above the measured one; the measured number falls inside the stated range.
By their numbers in this assay, from the lowest: compounds 2, 4, 3 and 1 (each within the scatter of the next, the first and the last beyond it).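

The step to 2-hydroxyphenyl on this carbonyl carbon, a 1.3-fold higher number from compound 2 to compound 4 (0.10 log units; within the scatter), shows that a ring of carbon only can stay level with 5-methoxypyridin-3-yl, so a ring nitrogen is not required here. Replacing methyl with hydrogen on the ring oxygen gives a 1.9-fold lower number from compound 3 to compound 4 (0.28 log units; within the scatter), so that change cannot be told apart from scatter, whereas the change from pyridin-2-yl gives a real difference, a 2.3-fold lower number from compound 1 to compound 4 (0.36 log units; beyond the scatter). Nothing available explains these steps. Still open, from the compounds shown here alone, is how an amine or a carboxylic acid would compare in place of the hydroxy group.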